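The source may report more compounds than this note shows. Statements on the series, on what has been measured and on what is new or still open speak of the compounds shown alone.

Among the measured compounds shown here, in a functional assay on the whole organism for antagonist activity, with Mus musculus as the target (on this read-out lower numbers stand for an effect already at smaller amounts and higher numbers for an effect only at larger amounts of compound), compound 3 `COc1ccc(CN2CCC(C(=O)Nc3cc(Cl)c(N)cc3OC)CC2)cc1` gives 0.9 mg/kg, the only real number among the three measured values. Compound 1 `COc1cc(N)c(Cl)cc1NC(=O)C1CCN(C2CCCC2)CC1` gives only a limit, > 10 mg/kg. Compound 2 `COc1cc(N)c(Cl)cc1NC(=O)C1CCN(CC2CC2)CC1` likewise gives only a limit, > 10 mg/kg. Compound 4 `CCCCCN1CCC(C(=O)Nc2cc(Cl)c(N)cc2OC)CC1` differs from compound 3 by butyl in place of 4-methoxyphenyl on a saturated chain carbon bound to an amine nitrogen in a ring. The measured steps that bear on this change run the other way: an at least 11-fold lower number from compound 2 to compound 3 (1.04 log units; beyond the scatter) and an at least 11-fold lower number from compound 1 to compound 3 (1.04 log units; beyond the scatter), both read against (the limit of > 10 mg/kg in this assay, at which 2 of the 3 values shown sit). Replacing the aromatic group with a plain butyl chain is therefore expected to raise the number in this assay by a large step, an 11-fold higher number from compound 3 to compound 4 (1.05 log units; beyond the scatter). Compound 4 is expected to give 10 mg/kg, between 3 mg/kg and 30 mg/kg, quite possibly reported again only as a limit.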

Compound 4, dose for half-maximal effect: > 10 mg/kg
Compound 4: no number, only a limit; the forecaster's own chance of this, stated with the estimate: 60%; the middle value sits exactly at the limit.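

With butyl in place of 4-methoxyphenyl, this assay shows an at least 11-fold higher number from compound 3 to compound 4 (1.04 log units; beyond the scatter), so the step seen with the cyclic groups of compound 1 and compound 2 also appears with an open chain. Of the groups shown at this place, only the 4-methoxybenzyl of compound 3 gives a real number. Compound 4 gives only a limit, and its steps from compound 1 and compound 2 cannot be read: the limit of > 10 mg/kg in this assay, at which 3 of the 4 values shown sit.

Still open, on these data alone, is whether the aromatic ring alone or the methoxy on it goes with the lower number. A plain benzyl or a 4-chlorobenzyl at this place would bear on that.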